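The source may hold more compounds than are shown below. What is called first, only, known or untested is meant among the compounds shown, and "the series" means these compounds.

Measured compounds:
compound 1 `O=C(CCCCSCc1ccccc1)c1ncc(-c2ccccn2)o1` — 25 nM
compound 2 `CCCCCCCC/C=C\CCCCCCC(=O)c1ncc(-c2ccccn2)o1` — 18 nM
compound 3 `CCCCCCCC/C=C\CCCCCCC(=O)c1nc2cc(C)ccc2o1` — > 100000 nM

In an assay on isolated protein for inhibition of Fatty-acid amide hydrolase 1 (Homo sapiens) (on this read-out lower numbers stand for stronger inhibition and higher numbers for weaker inhibition), compound 2 gives 18 nM, the lowest of the two plain numbers. Compound 1, with 25 nM, sits close by, and the gap between the two lies within the usual scatter, so neither can be called the stronger. For compound 3 the assay reports only a limit, > 100000 nM, so that compound supplies no number at all (the limit of > 100000 nM in this assay, at which 1 of the 3 values shown sits).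

Compound 4 `CCCCCCCC/C=C\CCCCCCC(=O)c1ncc(-c2ccncc2)o1` keeps the long unsaturated chain and the ketone of compound 2 and differs only in one place: pyridin-4-yl in place of pyridin-2-yl on an aromatic carbon. Among the measured compounds shown here, no measured pair shows this exact change, so its effect has to be estimated. Swapping the point at which the pyridine ring is attached is a small change in atoms but a real change in shape, and a moderate weakening seems more likely than a gain. Expected is a step of a 5.0-fold higher number from compound 2 to compound 4 (0.70 log units; beyond the scatter), with a fair chance that it stays within the scatter. Compound 4 is therefore estimated at 90 nM, with a range from 20 nM to 600 nM.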

Compound 4, inhibition constant: 56 nM
The estimate for compound 4 lay 1.6-fold (0.21 log units) above the measured number, and the stated range covers the measured number.
By their numbers in this assay, from the lowest: compounds 2 and 1 (each within the scatter of the next); then compound 4. At a limit, above all of these: compound 3.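

Moving the attachment point of the pyridine ring, with the same atoms and the same counted features, is enough to show up in this assay as a 3.1-fold higher number from compound 2 to compound 4 (0.49 log units; beyond the scatter) on the carbon next to the ring oxygen, a first direct reading at this position, since compound 1 and compound 2 both carry pyridin-2-yl there. The step is modest, so at least with this long unsaturated chain, the position accepts pyridin-4-yl and compound 4 still gives a plain number. Nothing measured here accounts for the size of this step.

Open, on these data alone, is how pyridin-3-yl or a plain phenyl ring would read on the same carbon, which would show whether the ring nitrogen matters at all. Also open, as far as these compounds go, is whether pyridin-4-yl would give a similar step on the chain of compound 1.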